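The source may report more compounds than this note shows. Statements on the series, on what has been measured and on what is new or still open speak of the compounds shown alone.

In an assay on ileum for antagonist activity at histamine H1 receptor (Cavia porcellus), with a stated time of 15 min (a lower number here means tighter binding, a higher number weaker binding), compound 2 `CC(CC(=O)/N=C(\N)NCCCc1ncn[nH]1)c1ccccc1` gives 1480 nM, the lowest of the two numbers shown; compound 1 `N/C(=N\C(=O)CC(c1ccccc1)c1ccccc1)NCCCn1ccnc1` gives 2340 nM in this assay, and the two values lie within the scatter of each other. Compound 3 `N/C(=N\C(=O)CC(c1ccccc1)c1ccccc1)NCCCc1ncn[nH]1` differs from compound 2 by phenyl in place of methyl on a saturated chain carbon bound to an aromatic carbon and a saturated chain carbon. No pair of measured compounds shows this change alone, so its size cannot be read from a shown step. Compound 3 is expected to stay close to compound 2, with a step of a 1.4-fold higher number from compound 2 to compound 3 (0.13 log units; within the scatter) not beyond the scatter. For compound 3 the estimated value is 2000 nM, within 700 nM to 6000 nM.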

Compound 3, dissociation constant: 1620 nM
Compound 3: the middle estimate sits 1.2-fold (0.09 log units) above what was measured, within the range that was stated.
By their numbers in this assay, from the lowest: compounds 2, 3 and 1 (each within the scatter of the next).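

In this assay, phenyl in place of methyl on a saturated chain carbon bound to an aromatic carbon and a saturated chain carbon gives a step within the scatter (a 1.1-fold higher number from compound 2 to compound 3 (0.04 log units; within the scatter)), so this position holds either group with no readable difference. The same holds for 1H-1,2,4-triazol-5-yl in place of 1H-imidazol-1-yl on a saturated chain carbon, three bonds along the chain from an amine nitrogen (a 1.4-fold lower number from compound 1 to compound 3 (0.16 log units; within the scatter)). Nothing available explains either result. As far as these compounds go, whether an amine or a carboxylic acid at the phenyl position would give a step beyond the scatter remains open.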